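From One Chlorine to Two on the Pendant Phenyl

The source may report more compounds than this note shows. Statements on the series, on what has been measured and on what is new or still open speak of the compounds shown alone.

Compound 1, `Cc1cc(=O)c2c(O)cc(OCc3ccco3)c([C@H]3CCN(C)C[C@H]3O)c2o1`, gives 32% in a functional assay on HL-60 cells (Homo sapiens) for inhibition, read by MTT assay, with a stated time of 48 h, tested at 10 uM; a higher number here means more inhibition of growth at the concentration tested, a lower number less inhibition of growth.
Compound 2, `Cc1cc(=O)c2c(O)c(CN(C(C)C)C(C)C)c(O)c([C@H]3CCN(C)C[C@H]3O)c2o1`, gives 21% in this assay.
Compound 3, `Cc1oc2c([C@H]3CCN(C)C[C@H]3O)c(O)cc(O)c2c(=O)c1C(O)c1ccc(Cl)cc1`, gives 2% in this assay.

Among these three numbers compound 3 stands lowest. Compound 2 is the nearest to it, yet the gap between the two lies beyond the usual scatter of repeated measurements, and compound 1 is furthest, with a gap that is larger still. Compound 3 therefore shows little growth inhibition at the tested concentration, while the other two show clearly more. Within the data shown here, none of these three pairs differs in just one place, so no single structural step between measured compounds can be read off.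

Compound 4, `Cc1oc2c([C@H]3CCN(C)C[C@H]3O)c(O)cc(O)c2c(=O)c1C(O)c1cccc(Cl)c1Cl`, is the next compound to be measured in this assay. It differs from compound 3 in one place: 2,3-dichlorophenyl in place of 4-chlorophenyl on a saturated chain carbon bound to an aromatic carbon and an oxygen on a saturated carbon. Among the measured compounds shown here, with no measured step of this kind to lean on, the expectation rests on the low value of compound 3 alone. The expected step is a number 6 percentage points higher from compound 3 to compound 4 (within the scatter), a small one, not beyond the scatter, though a slight rise cannot be ruled out. For compound 4 the estimated value in this assay is 8%, within a range from 0% to 24%.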

Compound 4, percent growth inhibition at one concentration: 12%
For compound 4 the middle estimate is 4 percentage points below the measured one; the measured number falls inside the stated range.
By their numbers in this assay, from the lowest: compounds 3, 4 and 2 (each within the scatter of the next, the first and the last beyond it); then compound 1.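

Replacing (4-chlorophenyl)(hydroxy)methyl with (2,3-dichlorophenyl)(hydroxy)methyl gives a number 10 percentage points higher from compound 3 to compound 4 (within the scatter) in this assay. Among these compounds, this is the first comparison here in which only one place on the shared core changes, so it gives a direct look at this position, which the earlier compounds could not provide: swapping one chlorinated phenyl for the other produces no change that can be told apart from ordinary measurement scatter. No measurement shown here explains how these two compounds compare.

The step also changes both the number of chlorine atoms and where they sit on the phenyl ring, so this single comparison cannot separate those two changes, and a ring with 2-chlorophenyl or 3-chlorophenyl alone would be needed to pull them apart. On these data alone, whether an unsubstituted phenyl, a methoxyphenyl, a pyridine ring or a group carrying a carboxylic acid or an amine at this place would move the number beyond the scatter remains open.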